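The source may hold more compounds than are shown below. What is called first, only, known or untested is meant among the compounds shown, and "the series" means these compounds.

- compound 1 `Cc1ccc2c(O)nc(-c3ccccc3)cc2c1` gives 1700 nM
- compound 2 `Cc1ccc(-c2cc3cc(C)ccc3c(O)n2)cc1` gives 4900 nM
- compound 3 `CN1CCN(c2nc(-c3ccc(Cl)cc3)cc3c(N(C)C)cccc23)CC1` gives 7560 nM

In a functional assay on SK-OV-3 cells (Homo sapiens) for cytotoxicity (on this read-out higher numbers stand for weaker inhibition and lower numbers for stronger inhibition), compound 3 stands at 7560 nM, within the scatter of compound 2 . Compound 1 has a lower number, and its gap to compound 3 lies beyond the scatter.

The next analogue, compound 4 `COc1ccc(-c2cc3c(N(C)C)cccc3c(N3CCN(C)CC3)n2)cc1`, keeps the core of compound 3 and carries methoxy in place of chloro on an aromatic carbon, para to a large group: methoxy in place of chloro on an aromatic carbon. The same difference reads as 4-chlorophenyl to 4-methoxyphenyl.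

For the measured compounds named here, no measured pair in this set makes this exchange. Going by the values given here, the only measured step is a 2.9-fold higher number from compound 1 to compound 2 (0.46 log units; beyond the scatter), a modest one, and it is methyl in place of hydrogen on an aromatic carbon, on a different core. It offers only a loose guide: a single small change on an aromatic carbon moved the number modestly upward. Its direction cannot be carried over with any confidence, so no step beyond the scatter is expected in this assay. The expected step is a 1.1-fold lower number from compound 3 to compound 4 (0.03 log units; within the scatter), and this estimate remains uncertain.

For compound 4 the estimated value is 7000 nM, with an expected range from 2800 nM to 17000 nM.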

Compound 4, half-maximal inhibitory concentration: 13200 nM
Compound 4: the middle estimate sits 1.9-fold (0.28 log units) below what was measured; low and high end bracket the measured number.
By their numbers in this assay, from the lowest: compound 1; then compounds 2, 3 and 4 (each within the scatter of the next, the first and the last beyond it).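

In this assay, methoxy in place of chloro on an aromatic carbon, para to a large group, gives a 1.7-fold higher number from compound 3 to compound 4 (0.24 log units; within the scatter), so on this core the 4-chlorophenyl and 4-methoxyphenyl forms cannot be told apart, even though methoxy brings a hydrogen-bond acceptor that chloro lacks. For the compounds shown here, the only earlier step, a 2.9-fold higher number from compound 1 to compound 2 (0.46 log units; beyond the scatter), is a different exchange on a different core and says nothing about this position, so this pair gives the first reading here: one exchange at this place leaves the number within the scatter. No measurement at hand accounts for the two groups reading alike.

From the compounds shown here alone, whether this place accepts other kinds of group stays open: a single pair cannot show whether an amine, a carboxylic acid or a longer chain such as butoxy at the same carbon would also stay within the scatter of compound 3. Compounds 3 and 4 differ from compounds 1 and 2 in more than one place, so the contribution of the dimethylamino and methylpiperazine groups on their core cannot be read from these compounds.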